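Adding chloro to the fluorobenzyl ring of compound 3

A few compounds are considered here, and "the series" means these few. Any claim that something is new, unique, unknown or untested is made for them only; others in the source may bear on it.

In a functional assay on A2780 cells (Homo sapiens) for antiproliferative activity, read by resazurin assay, with a stated time of 72 h (a lower number here means a stronger inhibitor, a higher number a weaker inhibitor), compound 1 `Cc1cccc(Cc2n[nH]c3cc(O)c(C(=O)NCc4ccccc4)cc23)c1` gives only a limit, > 10000 nM. Compound 2 `Cc1cccc(Cc2n[nH]c3cc(O)c(C(=O)N(C)Cc4ccccc4)cc23)c1` gives 490 nM and compound 3 `Cc1cccc(Cc2n[nH]c3cc(O)c(C(=O)N(C)Cc4cccc(F)c4)cc23)c1` gives 440 nM, so these two stand level within the scatter. Compound 4 `Cc1cccc(Cc2n[nH]c3cc(O)c(C(=O)N(C)Cc4ccc(Cl)c(F)c4)cc23)c1` has chloro in place of hydrogen on an aromatic carbon of compound 3, ortho to a fluoro group and para to a large group (chloro in place of hydrogen on an aromatic carbon). The nearest measured change is a 1.1-fold lower number from compound 2 to compound 3 (0.05 log units; within the scatter), also a halogen on that ring, and it stayed within the scatter. The large at least 20-fold lower number from compound 1 to compound 2 (1.30 log units; beyond the scatter) came from methyl on the amide-type nitrogen, which compound 4 keeps. The estimated step is a 1.2-fold lower number from compound 3 to compound 4 (0.06 log units; within the scatter), an expected change no larger than the scatter. Compound 4 is expected at 380 nM, with an estimated range of 160 nM to 900 nM.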

Compound 4, half-maximal inhibitory concentration: 930 nM
Beside the measured number, compound 4's estimate is 2.4-fold (0.39 log units) below it; measured number outside the range, above it.
By their numbers in this assay, from the lowest: compounds 3, 2 and 4 (each within the scatter of the next, the first and the last beyond it). At a limit, above all of these: compound 1.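

Chloro para to a large group gives a 2.1-fold higher number from compound 3 to compound 4 (0.33 log units; beyond the scatter) in this assay, so this ring position, unlike the fluoro change, responds measurably to substitution. Measured against the unsubstituted benzyl ring, the picture is a 1.9-fold higher number from compound 2 to compound 4 (0.28 log units; within the scatter), so the two halogens together leave the number level with that ring. Nothing shown here accounts for the shift. The compounds shown leave open whether a methyl, a methoxy or an amine at this position would also raise the number, and whether chloro would do so without the fluoro group.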